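Free phenol in place of the alkenyl ether

This account rests on a few compounds, and the source may have more. Where it says the series, first, only, none or still open, it means among the compounds named here.

Working notes on a small set of dimethoxy cinnamyl derivatives. Compound 1 `COc1cc(/C=C/C=O)cc(OC)c1OC/C=C(\C)CCC=C(C)C` gives 23000 nM in a functional assay on LoVo cells (Homo sapiens) for cytotoxicity, read by MTT assay, with a stated time of 72 h; a higher number here means a weaker inhibitor, a lower number a stronger inhibitor. Compound 3 `COc1cc(/C=C/CO)ccc1OC/C=C(\C)CCC=C(C)C` gives 27000 nM in this assay; the two values lie within the usual scatter of each other, so no order between them is claimed. Compound 2 `C=C(C)CCOc1c(OC)cc(/C=C/CO)cc1OC` stands apart: in this assay compound 2 reports only a limit of the assay, > 100000 nM, and no number. Of the three values shown, this is the one that sits at the limit of > 100000 nM in this assay, at which 1 of the 3 values shown sits.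

Compound 4 `COc1cc(/C=C/CO)cc(OC)c1O` is the next member to be measured. It differs from compound 2 in one place: hydrogen in place of 3-methylbut-3-en-1-yl on an oxygen on an aromatic ring. Going by the values given here, no step between measured compounds covers this change, so its size can only be expected, not read off. Since compound 2 already sits at a limit, the step from compound 2 to compound 4 is expected to be small or none beyond the scatter, a step that the limit leaves unreadable from compound 2 to compound 4, with a weak outcome the likelier one. Compound 4 is therefore estimated at 150000 nM in this assay, within a range of 50000 nM to 500000 nM, and a renewed limit rather than a number is the more probable readout.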

Compound 4, half-maximal inhibitory concentration: > 100000 nM
Compound 4 was reported as a limit; the forecaster's own chance of this, stated with the estimate: 70%; the middle value is on the limit's open side.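

Compound 2 and compound 4 both report only a limit of the assay, and no step can be read between them. The compounds shown leave open whether hydrogen in place of 3-methylbut-3-en-1-yl on that oxygen changes the outcome in this assay at all.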